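Methoxy to nitro on two thiourea-derived scaffolds

The compounds below may be only part of what the source reports. "The series", "measured", "known", "first", "only" and "open" are said of these compounds alone.

Compound 1 `COc1ccc(-c2nc(N(c3ccccc3)c3ccccc3)sc2C(=O)c2ccccc2)cc1`: 92.8%
Compound 2 `O=C(c1ccccc1)c1sc(N(c2ccccc2)c2ccccc2)nc1-c1ccc([N+](=O)[O-])cc1`: 79.6%
Compound 3 `COc1ccc(C(=O)NC(=S)N(c2ccccc2)c2ccccc2)cc1`: 19.2%

In an assay for inhibition of Polyunsaturated fatty acid 5-lipoxygenase (Homo sapiens), read by spectrophotometry, tested at 10 uM (on this read-out lower numbers stand for less inhibition and higher numbers for more inhibition at the one concentration tested (going by the name of the read-out)), compound 1 gives 92.8% and compound 2 gives 79.6%. The step between them, a number 13.2 percentage points lower from compound 1 to compound 2 (beyond the scatter), is the change (nitro in place of methoxy on an aromatic carbon). Compound 3 gives 19.2% in this assay, the lowest of the three; how its core differs from that of compound 1 is not broken down here. Compound 4 `O=C(NC(=S)N(c1ccccc1)c1ccccc1)c1ccc([N+](=O)[O-])cc1` is not yet measured. It differs from compound 3 by nitro in place of methoxy on an aromatic carbon, the same change as from compound 1 to compound 2. Because compound 3 already stands at 19.2%, the expected step of a number 7.2 percentage points lower from compound 3 to compound 4 (within the scatter) is smaller than the earlier one in this assay. Compound 4 is estimated at 12%, between 0% and 30%.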

Compound 4, a percentage reported as inhibition, at one concentration (the size of the read-out at that concentration, not a potency): 30.9%
The estimate for compound 4 lay 18.9 percentage points below the measured number, and the stated range ends below it.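

In this assay, nitro in place of methoxy gave a number 11.7 percentage points higher from compound 3 to compound 4 (beyond the scatter), so the step on this core runs the opposite way to the one on the core of compound 1: the same change on two cores in this assay, a number 13.2 percentage points lower (beyond the scatter) from compound 1 to compound 2 and a number 11.7 percentage points higher (beyond the scatter) from compound 3 to compound 4, 24.9 percentage points apart, beyond the scatter of two such steps

Within these two pairs, the size and direction of the change on one core therefore did not carry over to the other. Within the data shown here, with only one pair on each core, this does not show what in the cores sets the direction, nor how the change would run on a third core.

The compounds shown leave open whether an amine or a carboxylic acid in place of methoxy on this ring would follow either direction. They also leave open whether a chloro group there would separate the two cores in the same way.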